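The compounds below may be only part of what the source reports. "The series", "measured", "known", "first", "only" and "open" are said of these compounds alone.

Working notes on the series, read in a physicochemical assay for lipophilicity (on this read-out lower numbers stand for lower lipophilicity and higher numbers for higher lipophilicity), for now. Compound 1 `CCSc1ccccc1C1=NC(c2ccccc2)CO1` gives 4.04 and stands highest of the two measured compounds. Compound 2 `Fc1cccc(F)c1C1=NC(c2ccccc2)CO1` gives 3.01 and so lies lower, with a gap beyond the usual scatter. These two compounds differ in more than one place, so their gap gives no measure for a single change.

The next compound for this read-out is compound 3 `Ic1ccccc1C1=NC(c2ccccc2)CO1`, which keeps the core of compound 1 and carries iodo in place of ethylsulfanyl on an aromatic carbon with the group ortho to a large group. Within the data shown here, no measured step covers this swap, so the expectation rests on the structural change alone. Compound 3 is expected to stay close to compound 1 at 4.04 in this assay with at most a slight drop. The estimated change is a number 0.19 log units lower from compound 1 to compound 3 (within the scatter) and no step beyond the scatter is expected. The estimated value for compound 3 is 3.85 with an expected range from 3.45 to 4.25 for the coming measurement.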

Compound 3, partition coefficient: 3.86
Beside the measured number, compound 3's estimate is 0.01 log units below it, and the stated range covers the measured number.
By their numbers in this assay, from the lowest: compound 2; then compounds 3 and 1 (each within the scatter of the next).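

With this step the series has its first single-place comparison in this assay, at an aromatic carbon ortho to a large group. Iodo in place of ethylsulfanyl gives a number 0.18 log units lower from compound 1 to compound 3 (within the scatter), so at this place the exchange of a chain of 3 heavy atoms, one of them sulfur and counted as a hydrogen-bond acceptor, for a single iodine with no acceptor leaves the two compounds within the scatter of each other. Nothing measured here bears on why the read-out stays within the scatter across this swap.

Among these compounds, the result covers only this one exchange at this one place, so how an amine, a carboxylic acid or a longer chain such as butylsulfanyl would read at the same carbon stays open, as does whether the same swap gives a similar step on another aromatic carbon. Compound 2 still differs from compound 1 and compound 3 in more than one place, so no single change connects it to them, and what its two fluoro groups contribute separately in this assay remains unresolved.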